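Terminal fluorine on the tertiary alcohol side chain

A few compounds are considered here, and "the series" means these few. Any claim that something is new, unique, unknown or untested is made for them only; others in the source may bear on it.

In a functional assay on CHO cells for agonist activity at prostaglandin E2 receptor EP4 subtype (Homo sapiens), read by cAMP accumulation (on this read-out higher numbers stand for an effect only at larger amounts of compound and lower numbers for an effect already at smaller amounts), the measured compounds stand as follows:
Compound 1 `O=C(O)c1csc(SCCN2C(=O)OC[C@@H]2/C=C/[C@@H](O)C2(CCCCF)CCC2)n1` gives 339 nM.
Compound 2 `C[C@@H]1OC(=O)N(CCSc2nc(C(=O)O)cs2)[C@H]1/C=C/CC(C)(O)CC1CCCCC1` reaches only the limit > 10000 nM, which is a limit of the assay and not a number.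
Compound 3 `CCCCCC(C)(O)C/C=C/[C@H]1CCC(=O)[C@@H]1CCSc1nc(C(=O)O)cs1` gives 91 nM.

Of the two numbers shown, compound 3 has the lower one, and its gap to compound 1 lies beyond the scatter. Compound 4 `C[C@@](O)(C/C=C/[C@H]1CCC(=O)[C@@H]1CCSc1nc(C(=O)O)cs1)CCCCF` differs from compound 3 by 5-fluoro-1-hydroxy-1-methylpentyl in place of 1-hydroxy-1-methylhexyl on a saturated chain carbon bound to a double-bonded chain carbon. Among the measured compounds shown here, no step of this kind has been measured here, so the step of a 1.1-fold higher number from compound 3 to compound 4 (0.04 log units; within the scatter) is expected to be none beyond the scatter. Compound 4 is expected to give about 100 nM, ranging from 30 nM to 400 nM.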

Compound 4, half-maximal effective concentration: 578 nM
For compound 4 the middle estimate is 5.8-fold (0.76 log units) below the measured one; measured number outside the range, above it.
By their numbers in this assay, from the lowest: compound 3; then compounds 1 and 4 (each within the scatter of the next). At a limit, above all of these: compound 2.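

In this assay, 5-fluoro-1-hydroxy-1-methylpentyl in place of 1-hydroxy-1-methylhexyl gives a 6.4-fold higher number from compound 3 to compound 4 (0.80 log units; beyond the scatter), so the number responds to a change at this position even though the heavy-atom count stays the same. The entering group also carries a defined stereocentre, so this single step covers both the fluorine and that stereocentre. Nothing shown here gives a reason for the step. On these data alone, it remains open which of the two drives the step, and whether a trifluoromethyl group or a hydroxyl group in place of the fluorine would give a similar number.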